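Swapping fluoro for methyl on a weak compound

The source may hold more compounds than are shown below. What is called first, only, known or untested is meant among the compounds shown, and "the series" means these compounds.

Within the data shown here, in a functional assay on K562 cells (Homo sapiens) for inhibition, read by trypan blue exclusion, with a stated time of 72 h (a lower number here means a stronger inhibitor, a higher number a weaker inhibitor), compound 1 (`Cn1c(=O)c(S(=O)(=O)c2ccc(F)cc2)cc2cnc(Nc3ccc4cc[nH]c4c3)nc21`) gives 10000 nM and is the higher of the two numbers so far, while compound 2 (`Cn1c(=O)c(S(=O)(=O)c2ccc(F)cc2)cc2cnc(Nc3ccc4[nH]ccc4c3)nc21`) gives 200 nM as the lower one. Compound 3 (`Cc1ccc(S(=O)(=O)c2cc3cnc(Nc4ccc5cc[nH]c5c4)nc3n(C)c2=O)cc1`) differs from compound 1 by methyl in place of fluoro on an aromatic carbon, para to a large group (methyl in place of fluoro on an aromatic carbon). Among the measured compounds shown here, the one measured step (a 50-fold lower number from compound 1 to compound 2 (1.70 log units; beyond the scatter)) is large, but it is a different change, 1H-indol-5-yl in place of 1H-indol-6-yl, so no measured step bears on this swap. No step beyond the scatter is therefore expected in this assay here, and the estimated step (a 1.3-fold lower number from compound 1 to compound 3 (0.10 log units; within the scatter)) is small. The estimate for compound 3 is 8000 nM with an expected range of 2500 nM to 20000 nM as its spread.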

Compound 3, half-maximal inhibitory concentration: 15000 nM
Compound 3: the middle estimate sits 1.9-fold (0.27 log units) below what was measured; measured number inside the range.
By their numbers in this assay, from the lowest: compound 2; then compounds 1 and 3 (each within the scatter of the next).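

In this assay, going from 4-fluorophenyl to 4-methylphenyl gives a 1.5-fold higher number from compound 1 to compound 3 (0.18 log units; within the scatter), so the two numbers cannot be told apart. Among these compounds, this is the first reading of a change on this ring, and for this pair, fluoro and methyl serve alike at this place. Nothing measured here offers a reason for this result.

Going by these compounds, whether the same swap would read alike on compound 2, with its 1H-indol-5-yl group, remains open. So does the effect of an amine or a carboxylic acid at this place on the ring.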